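A few compounds are considered here, and "the series" means these few. Any claim that something is new, unique, unknown or untested is made for them only; others in the source may bear on it.

In a functional assay on HT-29 cells (Homo sapiens) for antiproliferative activity, read by sulforhodamine B assay, with a stated time of 48 h (a lower number here means a stronger inhibitor, a higher number a weaker inhibitor), compound 1 `CCc1ccccc1NS(=O)(=O)c1ccc(N2CCNC2=O)cc1` gives 240 nM and compound 2 `O=C1NCCN1c1ccc(S(=O)(=O)Nc2ccc3[nH]ccc3c2)cc1` gives 130 nM, two values that lie within the usual scatter of each other. Compound 3 `CCCCCCCc1ccc(NS(=O)(=O)c2ccc(N3CCNC3=O)cc2)cc1` gives > 1000 nM, and this is a limit of the assay, not a number. Where compound 3 truly stands is therefore not known, and it is the only one of the three compounds reported this way.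

Compound 4 `CC(C)Cc1ccc(NS(=O)(=O)c2ccc(N3CCNC3=O)cc2)cc1` has not yet been measured. It differs from compound 3 in a single place: isopropyl in place of hexyl on a saturated chain carbon bound to an aromatic carbon. In words, this is isopropyl in place of hexyl on a saturated chain carbon bound to an aromatic carbon, and the same difference can also be read as heptyl to isobutyl.

Within the data shown here, no pair of measured compounds shows what a change of this kind does, so any forecast here is loose. The best guide is compound 1, which holds the shared core and gives 240 nM. On that basis, a move toward stronger inhibition in this assay is expected, of a size that may only just clear the scatter. The estimated move is an at least 2.0-fold lower number from compound 3 to compound 4 (0.30 log units; that floor lies within the scatter). The expected value for compound 4 is 500 nM, with an estimated range from 150 nM to 2000 nM.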

Compound 4, half-maximal inhibitory concentration: > 1000 nM
Compound 4 was reported as a limit; the forecaster's own chance of this, stated with the estimate: 20%; middle value at least 2.0-fold (0.30 log units) from the limit.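

Compound 4 gives > 1000 nM and this is a limit of the assay, not a number. Compound 3 is also reported only as a limit, so no step can be read between compound 3 and compound 4: the limit of > 1000 nM in this assay, at which 2 of the 4 values shown sit.

The compounds shown leave open where compound 3 and compound 4 truly stand, and whether isopropyl in place of hexyl changes the result at all.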